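The source may hold more compounds than are shown below. What is called first, only, known or untested is meant among the compounds shown, and "the series" means these compounds.

Measured so far in a functional assay on OCI-Ly3 cells (Homo sapiens) for inhibition, read by CellTiter-Glo, with stated times of 48 h and 96 h; on this read-out lower numbers stand for stronger inhibition of growth and higher numbers for weaker inhibition of growth:
- compound 1 (`CC(C)[C@H](NC(=O)OCc1ccccc1)C(=O)N[C@@H](CO)C(=O)N[C@@H](CCCNC(=N)N)C(=O)CF`) gives 290 nM
- compound 2 (`CC(C)[C@H](NC(=O)c1ccc(Br)cc1)C(=O)N[C@@H](CO)C(=O)N[C@@H](CCCNC(=N)N)C(=O)CF`) gives 150 nM

Only these two numbers are available, and compound 2 (150 nM) lies within the scatter of compound 1 (290 nM). Compound 3 (`N=C(N)NCCC[C@H](NC(=O)[C@H](CO)NC(=O)[C@@H](NC(=O)c1ccc(Br)cc1)C1CCCCC1)C(=O)CF`) has not yet been measured. It differs from compound 2 in one place (cyclohexyl in place of isopropyl on a saturated chain carbon bound to an amide-type nitrogen and a carbonyl carbon) with cyclohexyl in place of isopropyl on a saturated chain carbon bound to an amide-type nitrogen and a carbonyl carbon.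

Within the data shown here, no measured step touches that place. Among the measured compounds shown here, the only step available (a 1.9-fold lower number from compound 1 to compound 2 (0.29 log units; within the scatter)) concerns 4-bromophenyl in place of benzyloxy on a carbonyl carbon and stays within the scatter, so it gives no measure of this change. The data favour neither direction, and in this assay no step beyond the scatter is expected. The estimated step (a 1.3-fold lower number from compound 2 to compound 3 (0.10 log units; within the scatter)) is a small one, though a larger move cannot be ruled out. Compound 3 is expected at 120 nM within an estimated range from 40 nM to 350 nM in this measurement.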

Compound 3, concentration for 50% growth inhibition: 240 nM
The estimate for compound 3 lay 2.0-fold (0.30 log units) below the measured number; the range from low to high includes it.
By their numbers in this assay, from the lowest: compounds 2, 3 and 1 (each within the scatter of the next).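

Cyclohexyl in place of isopropyl on a saturated chain carbon bound to an amide-type nitrogen and a carbonyl carbon gave, in this assay, a 1.6-fold higher number from compound 2 to compound 3 (0.20 log units; within the scatter), the first measured step at this place, which the earlier compounds had left unchanged. The count of heavy atoms in this group went from 3 carbon atoms to 6, and one six-membered non-aromatic ring of carbon only entered, yet the read-out moved no further than the scatter, so this place tolerates that exchange in compound 3 when 4-bromophenyl stands on the other carbonyl carbon. No other measurement bears on this result.

Going by these compounds, with only isopropyl and cyclohexyl seen at this place, it remains open whether a phenyl ring, a chain carrying an amine or a carboxylic acid, or a much shorter group such as methyl would move the number beyond the scatter. On these data alone, it is also open whether the same exchange would behave alike in a compound with benzyloxy on that carbonyl carbon, as in compound 1.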